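A few compounds are considered here, and "the series" means these few. Any claim that something is new, unique, unknown or untested is made for them only; others in the source may bear on it.

Three compounds of the series have numbers in a functional assay on HT-29 cells (Homo sapiens) for antiproliferative activity, read by MTT assay, with a stated time of 72 h; a higher number here means a weaker inhibitor, a lower number a stronger inhibitor. Compound 1 `COc1cc2c(Oc3ccc(NC(=O)NN4C(=O)CSC4c4c(F)cccc4F)cc3Cl)ccnc2cc1OCCCN1CCCC1` gives 480 nM. Compound 2 `COc1cc2c(Oc3ccc(NC(=O)NN4C(=O)CSC4c4c(F)cccc4F)c4ccccc34)ccnc2cc1OCCCN1CCCC1` gives 1860 nM. Compound 3 `CCN1CCN(CCCOc2cc3nccc(Oc4c(F)cc(NC(=O)NN5C(=O)CSC5c5c(F)cccc5F)cc4F)c3cc2OC)CC1` gives 73 nM, the lowest of the three; its gaps to compound 1 and to compound 2 both lie beyond the scatter, with compound 1 the nearer of the two and compound 2 the furthest away. Within the data shown here, no pair among the measured compounds differs in a single place, so no measured step is available.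

Compound 4 `COc1cc2c(Oc3c(F)cc(NC(=O)NN4C(=O)CSC4c4c(F)cccc4F)cc3F)ccnc2cc1OCCCN1CCN(C)CC1` is not yet measured. It differs from compound 3 in one place: hydrogen in place of methyl on a saturated chain carbon bound to an amine nitrogen in a ring. Among the measured compounds shown here, no measured step in this assay covers a change of this kind, and a change this small at a saturated chain carbon bound to an amine nitrogen in a ring is expected to move the number little, if at all beyond the scatter. The expected step from compound 3 to compound 4 is a 1.2-fold higher number from compound 3 to compound 4 (0.09 log units; within the scatter), meaning none beyond the scatter. Compound 4 is therefore estimated at 90 nM, in a range from 40 nM to 220 nM.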

Compound 4, half-maximal inhibitory concentration: 150 nM
Beside the measured number, compound 4's estimate is 1.7-fold (0.22 log units) below it; measured number inside the range.
By their numbers in this assay, from the lowest: compound 3; then compound 4; then compound 1; then compound 2.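

In this assay the change from 4-ethylpiperazin-1-yl to 4-methylpiperazin-1-yl gives a 2.1-fold higher number from compound 3 to compound 4 (0.31 log units; beyond the scatter), a modest step that still lies beyond the usual scatter. Among these compounds, as the first single-place comparison, it shows that the size of the alkyl group on this ring amine nitrogen can register in the read-out, with the ethyl of compound 3 giving the lower number. Nothing on hand accounts for the step.

A single step gives no trend with chain length at this position, and compounds 1 and 2 offer no single-place comparison with it. Open, going by these compounds, is how a propyl, an isopropyl or a 2-hydroxyethyl group on the same nitrogen would read, or a plain hydrogen there.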